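A few compounds are considered here, and "the series" means these few. Any claim that something is new, unique, unknown or untested is made for them only; others in the source may bear on it.

Measured so far:
compound 1 `COc1cc2c(Oc3ccc(NC(=O)c4nn(-c5ccccc5C)c(=O)cc4C)cc3F)ccnc2cc1OCCCN1CCCCC1` gives 2500 nM in a functional assay on U-87MG ATCC cells (Homo sapiens) for inhibition, read by MTT assay, with a stated time of 72 h; on this read-out lower numbers stand for stronger inhibition and higher numbers for weaker inhibition
compound 2 `COc1cc2c(Oc3ccc(NC(=O)c4nn(-c5cccc(F)c5)c(=O)cc4C)cc3F)ccnc2cc1OCCCN1CCCC1` gives 1700 nM in this assay

Compound 2 and compound 1 give numbers that lie within the usual scatter of each other, so neither stands apart. Compound 3 `COc1cc2c(Oc3ccc(NC(=O)c4nn(-c5cccc(F)c5)c(=O)cc4C)cc3F)ccnc2cc1OCCCN1CCCCC1` is not yet measured. It carries piperidin-1-yl in place of pyrrolidin-1-yl on a saturated chain carbon, three bonds along the chain from an oxygen on an aromatic ring, with compound 2 otherwise unchanged. Within the data shown here, no pair of measured compounds differing only in this way is available, so no step can be read off for it. The expectation is that the step from compound 2 to compound 3 stays within the scatter, at a 1.1-fold lower number from compound 2 to compound 3 (0.05 log units; within the scatter). For compound 3 the number in this assay is expected near 1500 nM, most likely between 600 nM and 4000 nM.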

Compound 3, half-maximal inhibitory concentration: 1500 nM
Beside the measured number, compound 3's estimate shows no gap at the digits printed; measured number inside the range.
By their numbers in this assay, from the lowest: compounds 3, 2 and 1 (each within the scatter of the next).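

In this assay, piperidin-1-yl in place of pyrrolidin-1-yl on the saturated chain carbon, three bonds along the chain from an oxygen on an aromatic ring, gives a 1.1-fold lower number from compound 2 to compound 3 (0.05 log units; within the scatter) and so does not separate the two rings at this position. On the aromatic nitrogen, 3-fluorophenyl in place of 2-methylphenyl gives a 1.7-fold lower number from compound 1 to compound 3 (0.22 log units; within the scatter) and also leaves the two compounds unseparated. No evidence is available that bears on either step. Still open, on these data alone, is whether morpholin-4-yl or 4-methylpiperazin-1-yl at the chain end would give a step beyond the scatter. The same question holds for unsubstituted phenyl on the aromatic nitrogen.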